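Dimethoxyphenyl to dihydroxyphenyl on compound 3

This account rests on a few compounds, and the source may have more. Where it says the series, first, only, none or still open, it means among the compounds named here.

In a functional assay on HL-60 cells (Homo sapiens) for inhibition, read by CCK-8 assay, with a stated time of 48 h (a lower number here means a stronger inhibitor, a higher number a weaker inhibitor), compound 3 (`COc1ccc(Oc2ccc(C(C)C)cc2-c2ccsc2S(=O)(=O)NCCNC(=S)Nc2cc(C(F)(F)F)cc(C(F)(F)F)c2)cc1OC`) gives 6900 nM and compound 2 (`CC(C)c1ccc(Oc2ccc(O)c(O)c2)c(-c2ccsc2S(=O)(=O)NCCNC(=S)Nc2ccc([N+](=O)[O-])cc2)c1`) gives 8800 nM within the scatter of compound 3, while compound 1 (`COc1ccc(Oc2ccccc2-c2ccsc2S(=O)(=O)NCCNC(=S)Nc2cc(C(F)(F)F)cc(C(F)(F)F)c2)cc1OC`) gives 2800 nM as the lowest number of the three. The change to compound 4 (`CC(C)c1ccc(Oc2ccc(O)c(O)c2)c(-c2ccsc2S(=O)(=O)NCCNC(=S)Nc2cc(C(F)(F)F)cc(C(F)(F)F)c2)c1`) is 3,4-dihydroxyphenyl in place of 3,4-dimethoxyphenyl on an oxygen on an aromatic ring with the rest of the structure unchanged. For the measured compounds named here, the one measured step of a 2.5-fold higher number from compound 1 to compound 3 (0.39 log units; beyond the scatter) came with isopropyl in place of hydrogen on an aromatic carbon, a different change, so it offers only a rough sense of size. Compound 2 at 8800 nM also holds 3,4-dihydroxyphenyl but differs elsewhere, so it gives no direct comparison. A small move toward a lower number is expected, estimated as a 2.0-fold lower number from compound 3 to compound 4 (0.29 log units; within the scatter) here. For compound 4 the estimate is 3500 nM and the expected range runs from 1200 nM to 9000 nM as a rough expectation.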

Compound 4, half-maximal inhibitory concentration: 8200 nM
Compound 4: the middle estimate sits 2.3-fold (0.37 log units) below what was measured, within the range that was stated.
By their numbers in this assay, from the lowest: compound 1; then compounds 3, 4 and 2 (each within the scatter of the next).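

In this assay, for the compounds shown here, 3,4-dihydroxyphenyl in place of 3,4-dimethoxyphenyl gives a 1.2-fold higher number from compound 3 to compound 4 (0.07 log units; within the scatter), the first direct reading of a change at this position. The swap brings in hydrogen-bond donors, yet the number stays within the scatter, so here the two groups cannot be told apart. Nothing available explains this result. Still open, going by these compounds, is whether a phenyl ring carrying an amine or a carboxylic acid at this position would also leave the number unmoved. Also open, on these data alone, is whether the same swap would read alike on compound 1 , which has no isopropyl.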